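This account rests on a few compounds, and the source may have more. Where it says the series, first, only, none or still open, it means among the compounds named here.

Among the measured compounds shown here, in a functional assay on A549 cells (Homo sapiens) for inhibition, read by colorimetric assay and MTT assay, with a stated time of 72 h (a higher number here means a weaker inhibitor, a lower number a stronger inhibitor), compound 2 `C=CCCCCOc1ccccc1-c1cnc(OC)n1C` gives 80000 nM and stands highest of the two numbers so far, with compound 1 `C=CCCCCOc1ccccc1-c1cnc(OCCCCC=C)n1C` lower at 7000 nM on the same scale. Compound 3 `C=CCCCCOc1ccccc1-c1cnc(OCCOCC=C)n1C` differs from compound 2 by (allyloxy)methyl in place of hydrogen on a saturated chain carbon bound to an oxygen on an aromatic ring and so carries (allyloxy)methyl in place of hydrogen on a saturated chain carbon bound to an oxygen on an aromatic ring. For the measured compounds named here, the only measured step at that place is an 11-fold higher number from compound 1 to compound 2 (1.06 log units; beyond the scatter) with pent-4-en-1-yl leaving. Read in reverse, it points to a large move toward a lower number in this assay here too. The expected change is a 6.7-fold lower number from compound 2 to compound 3 (0.82 log units; beyond the scatter) by this estimate. For compound 3 the estimated value is 12000 nM with an expected range from 4000 nM to 35000 nM in this measurement.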

Compound 3, half-maximal inhibitory concentration: 34000 nM
Estimate against measurement, compound 3: 2.8-fold (0.45 log units) below; the measured number falls inside the stated range.
By their numbers in this assay, from the lowest: compound 1; then compound 3; then compound 2.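

In this assay the change from methoxy to 2-(allyloxy)ethoxy gives a 2.4-fold lower number from compound 2 to compound 3 (0.37 log units; beyond the scatter) and shows that a chain carrying allyloxy also lowers the number at this place. The move is only partial: allyloxy in place of but-3-en-1-yl gives a 4.9-fold higher number from compound 1 to compound 3 (0.69 log units; beyond the scatter) and leaves compound 1 the lowest of the three. Nothing available here explains the difference between these two chains. On these data alone, it remains open how an amine or a carboxylic acid at the end of this chain, or a longer chain, would read in this assay and whether the terminal double bond matters.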